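The source may report more compounds than this note shows. Statements on the series, on what has been measured and on what is new or still open speak of the compounds shown alone.

Measured compounds and values:

compound 1 `Cc1noc(C)c1COC1CC(=O)Nc2c1c(C)nn2-c1ncnc2nc[nH]c12` — 5 nM
compound 2 `Cc1nn(-c2ncnc3nc[nH]c23)c2c1C(OCc1ccccc1Cl)CC(=O)N2` — 2 nM
compound 3 `Cc1nn(-c2ncnc3nc[nH]c23)c2c1C(OCc1ccccc1F)CC(=O)N2` — 4 nM

All three share one core and differ only in the aryl group on a saturated chain carbon bound to an oxygen on a saturated carbon. In a functional assay on HEK293 cells for agonist activity at G-protein coupled receptor 39 (Homo sapiens), read by scintillation proximity assay and inositol phosphate accumulation, with a stated time of 75 min, in the presence of a further agent that is not named here (on this read-out lower numbers stand for an effect already at smaller amounts and higher numbers for an effect only at larger amounts of compound), compound 3 gives 4 nM, the second highest of the three numbers; its nearest neighbour is compound 1 with 5 nM, its furthest compound 2 with 2 nM. For the measured compounds named here, the steps around compound 3 are small: a 1.3-fold lower number from compound 1 to compound 3 (0.10 log units; within the scatter) and a 2.0-fold higher number from compound 2 to compound 3 (0.30 log units; within the scatter), both within the scatter, while a 2.5-fold lower number from compound 1 to compound 2 (0.40 log units; beyond the scatter) is the only step that goes beyond it, and that one only modestly.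

Compound 4 `Cc1nn(-c2ncnc3nc[nH]c23)c2c1C(OCc1ccc(C#N)cc1)CC(=O)N2` is not yet measured. The change from compound 3 is 4-cyanophenyl in place of 2-fluorophenyl on a saturated chain carbon bound to an oxygen on a saturated carbon. Going by the values given here, no measured step covers a nitrile on this aryl group, nor a change in where the substituent sits on the ring, so the bearing of the known steps is indirect: they show only that swapping the aryl group moves the number little, compound 1 to compound 3 and compound 2 to compound 3 staying within the scatter. The step of a 1.3-fold higher number from compound 3 to compound 4 (0.10 log units; within the scatter) is therefore expected to be small and of uncertain direction, most likely within the scatter. Compound 4 is estimated at 5 nM, with a range of 1.5 nM to 16 nM.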

Compound 4, half-maximal effective concentration: 4 nM
The estimate for compound 4 lay 1.3-fold (0.10 log units) above the measured number; low and high end bracket the measured number.
By their numbers in this assay, from the lowest: compounds 2, 3, 4 and 1 (each within the scatter of the next, the first and the last beyond it).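

In this assay, the step to the nitrile-bearing ring is no change at the digits printed from compound 3 to compound 4 (within the scatter) and the steps from the other two compounds are a 2.0-fold higher number from compound 2 to compound 4 (0.30 log units; within the scatter) and a 1.3-fold lower number from compound 1 to compound 4 (0.10 log units; within the scatter) with none of the three leaving the scatter. The earlier compounds shown here covered only 2-chlorophenyl, 2-fluorophenyl and 3,5-dimethyl-1,2-oxazol-4-yl on this saturated chain carbon; compound 4 extends the tolerated set to 4-cyanophenyl, a group that brings a triple bond and a hydrogen-bond acceptor not counted in 2-fluorophenyl, and the number stays in the same narrow band. No supporting data bear on why the number holds across these aryl groups.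

In the change from 2-fluorophenyl to 4-cyanophenyl, the substituent and its place on the ring change together, so the compounds shown cannot separate the two, and a 4-fluorophenyl or 2-cyanophenyl group would be needed to do so. Every compound shown also keeps an aromatic ring on this carbon, which leaves open whether the number would hold with an amine or a carboxylic acid on that ring, or with a longer chain in place of the single saturated carbon.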